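The source may hold more compounds than are shown below. What is called first, only, known or untested is meant among the compounds shown, and "the series" means these compounds.

Within the data shown here, the three compounds measured so far share one core. In an assay on cells for agonist activity at ecdysone receptor (Bombyx mori), read by a luciferase reporter, with a stated time of 24 h (a lower number here means that less compound is needed, a higher number that more compound is needed for the effect), compound 1 `CC(C)(C)N(NC(=O)c1ccccc1)C(=O)c1ccc(Cl)cc1Cl` gives 117 nM, compound 2 `Cc1cc(C)cc(C(=O)N(NC(=O)c2ccccc2)C(C)(C)C)c1` gives 69.2 nM, and compound 3 `CC(C)(C)N(NC(=O)c1cccc(F)c1)C(=O)c1ccccc1Cl` gives 69.2 nM. Compound 3 thus stands level with compound 2 at the digits shown, the two together at the low end of the three numbers, and compound 1 lies within the scatter of both. Compound 4 `Cc1ccc(C(=O)NN(C(=O)c2ccccc2Cl)C(C)(C)C)cc1` differs from compound 3 in one place: 4-methylphenyl in place of 3-fluorophenyl on a carbonyl carbon. Among the measured compounds shown here, the only measured step, a 1.7-fold lower number from compound 1 to compound 2 (0.23 log units; within the scatter), also exchanges an aryl group on a carbonyl carbon and stays within the scatter; it bears only loosely on the present change, as it swaps a 2,4-dichlorophenyl for a 3,5-dimethylphenyl, neither of which occurs here. For the measured compounds named here, no measured step sets a 3-fluorophenyl against a 4-methylphenyl. On this basis the step of a 1.0-fold higher number from compound 3 to compound 4 (0.00 log units; within the scatter) is expected to amount to no change beyond the scatter in this assay. Compound 4 is estimated at 70 nM, within 30 nM to 170 nM.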

Compound 4, half-maximal effective concentration: 18.6 nM
Compound 4: middle estimate off by 3.8-fold (0.58 log units), on the high side, and the stated range ends above it.
By their numbers in this assay, from the lowest: compound 4; then compounds 2, 3 and 1 (each within the scatter of the next).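

In this assay, the exchange of 3-fluorophenyl for 4-methylphenyl on a carbonyl carbon gives a 3.7-fold lower number from compound 3 to compound 4 (0.57 log units; beyond the scatter), the first step among these compounds to lie beyond the scatter, so an exchange of aryl groups at this place can move the number measurably. The two groups match in heavy-atom count and in having one six-membered aromatic ring of carbon only, and neither has a hydrogen-bond donor or acceptor, yet the numbers differ, so these counts do not separate them. Nothing available here accounts for the difference. Among these compounds, the single pair leaves open whether the lower number follows from the methyl group that enters or from the fluorine that leaves, and whether it would hold with another aryl group elsewhere on the shared core. On these data alone, whether an ethyl or methoxy group in place of that methyl would give a number like that of compound 4 also stays open.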